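The source may hold more compounds than are shown below. What is called first, only, known or untested is meant among the compounds shown, and "the series" means these compounds.

Compound 3, with the structure `Fc1cccc(-c2nc(Nc3ccccc3F)c3cc(F)ccc3n2)c1`, was tested in a functional assay on U2OS cells (Homo sapiens) for cytotoxicity, read by MTT assay, with a stated time of 48 h; on this read-out lower numbers stand for stronger inhibition and higher numbers for weaker inhibition. In this assay compound 3 gives > 50000 nM, which is a limit of the assay and not a measured number. The two other compounds in the set sit the same way. Compound 1, with the structure `Fc1cccc(-c2nc(Nc3ccccc3)c3ccccc3n2)c1`, gives > 50000 nM, again a limit rather than a number. Compound 2, with the structure `Fc1ccc2nc(-c3ccccc3)nc(Nc3ccccc3)c2c1`, gives > 50000 nM, once more a limit. The picture is summed up by the limit of > 50000 nM in this assay, at which 3 of the 3 values shown sit, so no compound shown has yet produced an actual value, and no step between measured compounds exists to lean on.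

Compound 4, with the structure `Fc1cccc(-c2nc(Nc3ccccc3Br)c3cc(F)ccc3n2)c1`, remains to be measured. It differs from compound 3 in one place: bromo in place of fluoro on an aromatic carbon. The step from compound 3 to compound 4 in this assay is estimated at a step that the limit leaves unreadable from compound 3 to compound 4, which amounts to no change beyond the scatter, with a further limit the most likely outcome. Compound 4 is therefore expected to land near 60000 nM, somewhere in the range from 20000 nM to 200000 nM.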

Compound 4, half-maximal inhibitory concentration: > 50000 nM
Compound 4 ended at the assay's limit (the forecaster's own chance of this, stated with the estimate: 85%); the middle value does not contradict the limit.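

Compound 3 and compound 4 each give only a limit in this assay, not a number, so no step can be read for bromo in place of fluoro. What stays open is whether any change to these compounds would yield an actual value, as everything shown rests on one result: the limit of > 50000 nM in this assay, at which 4 of the 4 values shown sit.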